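The source may hold more compounds than are shown below. What is called first, only, known or untested is meant among the compounds shown, and "the series" means these compounds.

Compound 1 `Cn1nc(CN2CCCC2)nc1-c1ccc2ccsc2c1` and compound 2 `Cn1nc(CN2CCCC2)nc1-c1ccc(Cl)c(Cl)c1` share a core and differ in the aromatic group attached to it. In an assay on membranes from Jurkat cells for displacement of a labelled ligand from Sigma non-opioid intracellular receptor 1 (Homo sapiens), read by scintillation counting, with a stated time of 2 h (on this read-out higher numbers stand for weaker inhibition and lower numbers for stronger inhibition), compound 1 gives 64 nM, while compound 2 gives 22 nM; of the two numbers, compound 1 thus stands at the higher one, and the gap between them lies beyond the usual scatter. Compound 3 `Cn1nc(CN2CCCC2)nc1-c1ccc2cc(Cl)sc2c1` has not yet been measured. It differs from compound 1 by chloro in place of hydrogen on an aromatic carbon, on an aromatic carbon of a five-membered aromatic ring with one sulfur, part of a fused system of two rings, next to the ring sulfur. Among the measured compounds shown here, no pair of measured compounds shows this kind of change, so any expectation rests on compound 1 alone. The step of a 1.8-fold lower number from compound 1 to compound 3 (0.26 log units; within the scatter) is expected to be small, towards a lower number, and may not exceed the scatter. For compound 3 the estimate in this assay is 35 nM, within a range from 12 nM to 100 nM.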

Compound 3, inhibition constant: 37 nM
Compound 3: middle estimate off by 1.1-fold (0.02 log units), on the low side; low and high end bracket the measured number.
By their numbers in this assay, from the lowest: compounds 2, 3 and 1 (each within the scatter of the next, the first and the last beyond it).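

In this assay, among the compounds shown here, the step of a 1.7-fold lower number from compound 1 to compound 3 (0.24 log units; within the scatter) is the first reading of any change on the core of compound 1, and it lies within the usual scatter. Chloro in place of hydrogen on this aromatic carbon, on the five-membered aromatic ring with one sulfur and next to the ring sulfur, therefore leaves the number indistinguishable from that of the parent, so this position accepts a chlorine without a change that can be read here. This rests on a single pair of compounds.

As far as these compounds go, whether methyl, methoxy, an amine or a carboxylic acid on this same carbon would also stay within the scatter remains open, as does the effect of chloro on other aromatic carbons of the fused system. The data shown offer no explanation for this result.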